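A few compounds are considered here, and "the series" means these few. Any claim that something is new, unique, unknown or untested is made for them only; others in the source may bear on it.

Compound 1 `N#Cc1cnc(N2CCC(C(=O)N3N=CC[C@H]3c3cc(F)cc(F)c3)CC2)cn1`: 3.3 h
Compound 2 `O=C(C1CCN(c2cccnn2)CC1)N1N=CC[C@H]1c1ccccc1`: 2.32 h

In an ADME assay on cells (Hepatocyte, Homo sapiens) for metabolic stability (a lower number here means that the compound disappears faster, a higher number that the compound lasts longer), compound 1 gives 3.3 h and compound 2 gives 2.32 h, so the two numbers lie within the usual scatter of each other. Compound 3 `N#Cc1cc(N2CCC(C(=O)N3N=CC[C@H]3c3cc(F)cc(F)c3)CC2)ncn1` has the same atoms as compound 1, joined differently. The 5-cyanopyrazin-2-yl group on the amine nitrogen in a ring gives way to another group of the same make-up: a group of 8 heavy atoms (5 carbon, 3 nitrogen; one six-membered aromatic ring with 2 hetero atoms) in place of a group of 8 heavy atoms (5 carbon, 3 nitrogen; one six-membered aromatic ring with 2 hetero atoms), on an amine nitrogen in a ring. Going by the values given here, no measured pair shows what such a swap does, so no step beyond the scatter is expected in this assay. Compound 3 is expected to give 3 h, with an estimated range of 1.4 h to 6 h.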

Compound 3, half-life: 3.3 h
Compound 3: middle estimate off by 1.1-fold (0.04 log units), on the low side, within the range that was stated.
By their numbers in this assay, from the lowest: compounds 2, 1 and 3 (each within the scatter of the next).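

In this assay the swap of the 5-cyanopyrazin-2-yl group for a group of the same atoms, joined differently, on the amine nitrogen in a ring gives no change at the digits printed from compound 1 to compound 3 (within the scatter) in this pair. At this place, then, the half-life holds when the same atoms are rearranged within this aromatic ring. Nothing shown explains this result. Still open, as far as these compounds go, is whether an amine or a carboxylic acid in place of the nitrile would shift the half-life beyond the scatter. Also open, from the compounds shown here alone, is whether this swap would behave alike on the core of compound 2.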